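Swapping 4-Chlorophenyl for 2-Chlorophenyl in a Cytotoxicity Series

This account rests on a few compounds, and the source may have more. Where it says the series, first, only, none or still open, it means among the compounds named here.

Three compounds have been measured in an ADME assay on MT4 cells (Homo sapiens) for cytotoxicity, read by MTT assay, with a stated time of 4 days; a higher number here means that more compound is tolerated, a lower number that less compound is tolerated:

compound 1, `Cc1ccccc1-c1cc(C)c(Nc2ccnc(Nc3ccc(C#N)cc3)n2)c(C)c1`, which in this assay gives 3820 nM
compound 2, `Cc1cc(-c2c(C)cccc2C)cc(C)c1Nc1ccnc(Nc2ccc(C#N)cc2)n1`, which in this assay gives 2590 nM
compound 3, `Cc1cc(-c2ccc(Cl)cc2)cc(C)c1Nc1ccnc(Nc2ccc(C#N)cc2)n1`, which in this assay gives 4190 nM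

On the numbers shown, compound 3 sits at the top of the three, but the steps of a 1.1-fold higher number from compound 1 to compound 3 (0.04 log units; within the scatter) and a 1.6-fold higher number from compound 2 to compound 3 (0.21 log units; within the scatter) are both within the scatter, so the three compounds are not really separated. The step of a 1.5-fold lower number from compound 1 to compound 2 (0.17 log units; within the scatter) is also within the scatter.

The unmeasured compound 4 is `Cc1cc(-c2ccccc2Cl)cc(C)c1Nc1ccnc(Nc2ccc(C#N)cc2)n1`. Its change from compound 3 is 2-chlorophenyl in place of 4-chlorophenyl on an aromatic carbon. The two measured steps that touch the same outer ring, a 1.1-fold higher number from compound 1 to compound 3 (0.04 log units; within the scatter) and a 1.6-fold higher number from compound 2 to compound 3 (0.21 log units; within the scatter), each exchanged one substituted phenyl for another and each stayed within the scatter. Nothing in the data suggests that exchanging one chlorophenyl for another should do more. Compound 4 is therefore expected to give about 4000 nM, with a likely range from 2000 nM to 8000 nM. That estimate means an expected step of a 1.0-fold lower number from compound 3 to compound 4 (0.02 log units; within the scatter), within the scatter.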

Compound 4, half-maximal cytotoxic concentration: 3990 nM
Estimate against measurement, compound 4: 1.0-fold (0.00 log units) above, and the stated range covers the measured number.
By their numbers in this assay, from the lowest: compounds 2, 1, 4 and 3 (each within the scatter of the next).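

Exchanging 4-chlorophenyl for 2-chlorophenyl keeps the same atoms and only joins them differently, and in this assay this gives a 1.1-fold lower number from compound 3 to compound 4 (0.02 log units; within the scatter). The other two steps also stay within the scatter: replacing 2,6-dimethylphenyl with 2-chlorophenyl gives a 1.5-fold higher number from compound 2 to compound 4 (0.19 log units; within the scatter), and chloro in place of methyl gives a 1.0-fold higher number from compound 1 to compound 4 (0.02 log units; within the scatter), so among these compounds neither where the chlorine sits on the outer ring nor chloro versus methyl at the same place separates the numbers. No measurement shown here offers an explanation for this flat result.

Every compound shown carries a substituted phenyl ring at this place on the core. From the compounds shown here alone, it remains open whether an amine, a carboxylic acid or a saturated ring such as morpholine there would shift the number beyond the scatter.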